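This account rests on a few compounds, and the source may have more. Where it says the series, first, only, none or still open, it means among the compounds named here.

Measured so far:
compound 1, `Cc1cccc(C(=O)N2CCCC(C(=O)Nc3ccc(Cl)cc3)C2)c1`: 0%
compound 2, `O=C(Nc1cccc(Cc2ccccc2)c1)C1CCCN(C(=O)c2cc(C(F)(F)F)cc(C(F)(F)F)c2)C1`: 0%

In an ADME assay on PC-3 cells (Homo sapiens) for cytotoxicity, read by WST assay, tested at 100 uM (on this read-out lower numbers stand for less inhibition and higher numbers for more inhibition at the one concentration tested (going by the name of the read-out)), compound 1 gives 0%, and compound 2 gives 0%. The two values are level at the digits reported, so neither compound shows cell killing that rises out of the noise at the single concentration tested, and no order between them can be drawn. Among the measured compounds shown here, only two compounds have been measured, and they differ in several places at once, so no step between measured compounds can be set out.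

Compound 3, `Cc1nc(-c2cccc(C(=O)N3CCCC(C(=O)Nc4ccc(Cl)cc4)C3)c2)cs1`, is built from compound 1 by one change: 2-methyl-1,3-thiazol-4-yl in place of methyl on an aromatic carbon. The new group sits on an aromatic carbon of a six-membered aromatic ring of carbon only, meta to a large group. Nothing in the measured pair says what such a change does in this assay. The expectation for compound 3 therefore rests on compound 1 and its reading of 0%, and the step of a number 4 percentage points higher from compound 1 to compound 3 (within the scatter) is expected to stay within the scatter, with no clear direction. Compound 3 is thus estimated at 4%, in a range from -10% to 25%.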

Compound 3, a percentage reported as inhibition, at one concentration (the size of the read-out at that concentration, not a potency): 1%
The estimate for compound 3 lay 3 percentage points above the measured number; measured number inside the range.
By their numbers in this assay, from the lowest: compounds 1, 2 and 3 (each within the scatter of the next).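

In this assay, putting 2-methyl-1,3-thiazol-4-yl in place of methyl on the aromatic carbon gives a number 1 percentage points higher from compound 1 to compound 3 (within the scatter). Among the compounds shown here, this is the first comparison here in which only one place differs, and it shows that a much larger group, bringing a five-membered aromatic ring with 2 hetero atoms, can sit at this position, meta to a large group, without moving the reading beyond the scatter. Nothing measured here speaks to why the reading stays level.

On these data alone, it remains open whether an amine or a carboxylic acid on this same aromatic carbon would also leave the reading level. For the compounds shown here, the single step also cannot tell whether changes elsewhere on the core of compound 1 would behave in the same way.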